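Halogen exchange on the shared core

This account rests on a few compounds, and the source may have more. Where it says the series, first, only, none or still open, it means among the compounds named here.

Compound 3 `C[C@@H](NC(=O)Nc1ccccc1F)c1ccccc1` gives 95% in an ADME assay on the whole organism with Oryza sativa as the target, tested at 1 uM; a higher number here means a weaker effect of the compound at the concentration tested, a lower number a stronger effect. It stands level with compound 1 `C[C@@H](NC(=O)Nc1ccccc1C(F)(F)F)c1ccccc1`, which gives 95%, and within the scatter of compound 2 `COc1ccccc1NC(=O)N[C@H](C)c1ccccc1`, which gives 105%. Compound 4 `C[C@@H](NC(=O)Nc1ccccc1I)c1ccccc1` differs from compound 3 by iodo in place of fluoro on an aromatic carbon. Among the measured compounds shown here, the steps that bear on this exchange are no change at the digits printed from compound 1 to compound 3 (within the scatter) and a number 10 percentage points lower from compound 2 to compound 3 (within the scatter), both within the scatter, so three different groups in this place leave this assay unmoved. The expected step in this assay is a number 2 percentage points higher from compound 3 to compound 4 (within the scatter), none beyond the scatter. Compound 4 is therefore estimated at 97%, with a range from 82% to 112%.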

Compound 4, a percentage reported as activity, at one concentration (the size of the read-out at that concentration, not a potency): 100%
Estimate against measurement, compound 4: 3 percentage points below; the range from low to high includes it.
By their numbers in this assay, from the lowest: compounds 1, 3, 4 and 2 (each within the scatter of the next).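

With iodo, four groups at this aromatic carbon now give no step beyond the scatter in this assay, as the readings show a number 5 percentage points higher from compound 3 to compound 4 (within the scatter) and a number 5 percentage points higher from compound 1 to compound 4 (within the scatter) and a number 5 percentage points lower from compound 2 to compound 4 (within the scatter). Fluoro, iodo, trifluoromethyl and methoxy are thus not told apart at this place, so the insensitivity seen across the first three compounds extends to a second halogen. No available evidence bears on the reason for this flat reading.

As far as these compounds go, whether an amine or a carboxylic acid on this carbon would move the number remains open. So does the effect of any change elsewhere on the shared core.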